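A few compounds are considered here, and "the series" means these few. Any claim that something is new, unique, unknown or untested is made for them only; others in the source may bear on it.

Compound 1 `Nc1nn(C(=O)Nc2ccc(Cc3ccccc3)cc2)c2ccccc12` and compound 2 `Nc1nn(C(=O)Nc2ccc(Cc3ccccc3)cc2)c2ccc(Cl)cc12` share one core and differ by chloro in place of hydrogen on an aromatic carbon. In a functional assay on KM12 cells (Homo sapiens) for antiproliferative activity, read by sulforhodamine B assay, with a stated time of 48 h (on this read-out higher numbers stand for lower toxicity in this test and lower numbers for higher toxicity in this test), compound 1 gives > 100000 nM, which is a limit of the assay. In this assay compound 2 likewise gives > 100000 nM, again a limit. The step that the two limits leave unreadable from compound 1 to compound 2 cannot be read because of the limit of > 100000 nM in this assay, at which 2 of the 2 values shown sit. Compound 2 thus stands only at that limit, with no number beneath it. Compound 3 `Nc1ccc2c(c1)c(N)nn2C(=O)Nc1ccc(Cc2ccccc2)cc1` differs from compound 2 by amino in place of chloro on an aromatic carbon. Among the measured compounds shown here, only the step that the two limits leave unreadable from compound 1 to compound 2 bears on this change, and since it is unreadable, no size or direction for compound 3 in this assay can be derived from it. Compound 3 is therefore expected to stay at the same limit, with a step that the limit leaves unreadable from compound 2 to compound 3 estimated as none beyond the scatter. The estimate for compound 3 is 150000 nM, between 50000 nM and 500000 nM.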

Compound 3, concentration lethal to 50% of the cells: 41300 nM
For compound 3 the middle estimate is 3.6-fold (0.56 log units) above the measured one; the measured number lies below the stated range.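

This position on the six-membered aromatic ring of carbon only now gives a readable change in this assay: amino in place of chloro gives an at least 2.4-fold lower number from compound 2 to compound 3 (0.38 log units; beyond the scatter), and amino in place of hydrogen gives an at least 2.4-fold lower number from compound 1 to compound 3 (0.38 log units; beyond the scatter). The earlier pair showed nothing of this position, as hydrogen and chloro both left the read-out at a limit, whereas amino gives the first real number, on the side of higher toxicity in this test. Both steps are only lower bounds, since each starts from a limit and not a number: the limit of > 100000 nM in this assay, at which 2 of the 3 values shown sit.

On these data alone, how large the steps truly are stays open. So does how the number in this assay would move with another group at this position, such as a hydroxyl, a methylamino or an acetamide.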